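Bromoacyl Amides on Two Cores: Antiproliferative Potency Compared

This account rests on a few compounds, and the source may have more. Where it says the series, first, only, none or still open, it means among the compounds named here.

Compound 1, `CC(Br)C(=O)Nc1cc(C(=O)NC(N)=O)cc([N+](=O)[O-])c1`, gives 1580 nM in a functional assay on CCRF-CEM cells (Homo sapiens) for antiproliferative activity, read by trypan blue exclusion, with a stated time of 72 h; on this read-out lower numbers stand for stronger inhibition and higher numbers for weaker inhibition.
Compound 2, `NC(=O)NC(=O)c1cc(NC(=O)CBr)cc([N+](=O)[O-])c1`, gives 1530 nM in this assay.
Compound 3, `CC(Br)C(=O)Nc1cc(C(=O)NC(N)=O)cs1`, gives 3940 nM in this assay.

Compound 1 and compound 2 share one core, and compound 2 differs from compound 1 by hydrogen in place of methyl on a saturated chain carbon bound to a bromine atom and a carbonyl carbon. On this pair the change produced a 1.0-fold lower number from compound 1 to compound 2 (0.01 log units; within the scatter), so the two numbers cannot be told apart. Compound 3 stands on a different core; the difference between the two cores is not broken down here, and its number is the highest of the three, lying beyond the scatter from both compound 1 and compound 2.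

Compound 4, `NC(=O)NC(=O)c1csc(NC(=O)CBr)c1`, has not yet been measured. Relative to compound 3 it carries hydrogen in place of methyl on a saturated chain carbon bound to a bromine atom and a carbonyl carbon, the same change as that from compound 1 to compound 2, at the same place. For compound 4 the step is expected to be a 1.0-fold lower number from compound 3 to compound 4 (0.00 log units; within the scatter), which rests on a 1.0-fold lower number from compound 1 to compound 2 (0.01 log units; within the scatter) having stayed within the scatter. Compound 4 is therefore estimated at 3900 nM, with an expected range from 1900 nM to 8000 nM.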

Compound 4, half-maximal inhibitory concentration: 1130 nM
Compound 4: middle estimate off by 3.5-fold (0.54 log units), on the high side, outside the stated range (below it).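

In this assay, the change from 1-bromoethyl to bromomethyl gave a 3.5-fold lower number from compound 3 to compound 4 (0.54 log units; beyond the scatter), whereas the same change on the other core gave a 1.0-fold lower number from compound 1 to compound 2 (0.01 log units; within the scatter). Going by these compounds alone, the effect of this change therefore did not carry over unchanged from one core to the other, and a step read on one core was a poor guide to the step on the second: the same change on two cores in this assay, a 1.0-fold lower number (0.01 log units; within the scatter) from compound 1 to compound 2 and a 3.5-fold lower number (0.54 log units; beyond the scatter) from compound 3 to compound 4, 3.4-fold (0.53 log units) apart, beyond the scatter of two such steps With only one pair on each core, this shows that the outcome of the change depended on the core in these compounds, but it does not show which feature of the cores lies behind the gap or which step is the more typical for the series.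

The compounds shown leave open whether the same dependence on the core would appear with a chloromethyl group or a longer chain such as 1-bromopropyl in place of these groups. They also leave open how the change would behave on either core if a carboxylic acid replaced the acylurea group.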